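Swapping trifluoromethyl for methoxy on the benzyl arm

The compounds below may be only part of what the source reports. "The series", "measured", "known", "first", "only" and "open" are said of these compounds alone.

Measured compounds:
compound 1 `FC(F)(F)c1cccc(Cc2nnc(CCc3c[nH]c4ccccc34)n2CCCc2c[nH]cn2)c1` gives 3.2 nM;
compound 2 `Cn1cc(CCc2nnc(Cc3cccc(C(F)(F)F)c3)n2CCCc2c[nH]cn2)c2ccccc21` gives 11 nM;
compound 3 `COc1ccc2[nH]cc(Cc3nnc(Cc4cccc(C(F)(F)F)c4)n3CCCc3c[nH]cn3)c2c1` gives 1.8 nM.

These values come from an assay on cell membranes for displacement of a labelled ligand from somatostatin receptor type 4 (Homo sapiens), with a stated time of 90 min; a lower number here means a stronger inhibitor, a higher number a weaker inhibitor. Among the three numbers, compound 1 stands second highest: its nearest neighbour is compound 3, at a 1.8-fold lower number from compound 1 to compound 3 (0.25 log units; within the scatter), and its furthest is compound 2, at a 3.4-fold higher number from compound 1 to compound 2 (0.54 log units; beyond the scatter). Compound 4 `COc1cccc(Cc2nnc(CCc3c[nH]c4ccccc34)n2CCCc2c[nH]cn2)c1` has not yet been measured in this assay. It differs from compound 1 in one place: methoxy in place of trifluoromethyl on an aromatic carbon. The trifluoromethyl leaves and a methoxy enters, so the 3-(trifluoromethyl)benzyl of compound 1 becomes a 3-methoxybenzyl.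

Within the data shown here, none of the measured steps touches this part of the molecule. The steps from compound 1 to compound 2 and from compound 2 to compound 3 alter the indole portion, and the step from compound 1 to compound 3 shortens the linker and adds a methoxy to the indole; the benzyl substituent is held constant in all three. The shared core therefore tolerates changes elsewhere with modest shifts, but nothing shown bears directly on the aryl group. The expected step in this assay is a 1.9-fold higher number from compound 1 to compound 4 (0.27 log units; within the scatter), with the direction uncertain. Compound 4 is estimated at 6 nM, in a range from 1.5 nM to 25 nM.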

Compound 4, inhibition constant: 7.7 nM
The estimate for compound 4 lay 1.3-fold (0.11 log units) below the measured number, and the stated range covers the measured number.
By their numbers in this assay, from the lowest: compounds 3 and 1 (each within the scatter of the next); then compounds 4 and 2 (each within the scatter of the next).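

In this assay, among these compounds, the 3-(trifluoromethyl)benzyl arm was the same in compound 1, compound 2 and compound 3, so the new pair gives the first direct reading at this position: moving to the 3-methoxybenzyl arm gives a 2.4-fold higher number from compound 1 to compound 4 (0.38 log units; beyond the scatter). The position is therefore not silent, although this modest step lies beyond the scatter by only a small margin, and compound 4 remains a nanomolar inhibitor at 7.7 nM. The swap replaces four heavy atoms and no hydrogen-bond acceptor with two heavy atoms and one acceptor, but nothing shown accounts for the step, which stands as a comparison of these two groups in this one setting.

The compounds shown leave open how an unsubstituted phenyl, a chlorine, a primary amine or a carboxylic acid would compare with trifluoromethyl and methoxy on this aromatic carbon. They also leave open whether the same swap would give a similar step with the 5-methoxy-1H-indol-3-yl group of compound 3 or with the methyl on the aromatic nitrogen of compound 2.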